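The source may report more compounds than this note shows. Statements on the series, on what has been measured and on what is new or still open speak of the compounds shown alone.

Compound 2 `CCCC/C=C\CCCCCCCCCc1cc(=O)c2c(O)cc(OCOC)cc2o1` reaches no number in a functional assay on MDA-MB-231 cells (Homo sapiens) for antiproliferative activity, read by MTT assay; a lower number here means a stronger inhibitor, a higher number a weaker inhibitor; it stands only at a limit, giving > 87000 nM. Compound 1 `CCCC/C=C\CCCCCCCCCc1cc(=O)c2c(O)cc(OCOC)c(C)c2o1` is likewise a limit in this assay, where compound 1 gives > 87000 nM. Compound 3 `CCCC/C=C/CCCCCCCCCC1(O)CC(=O)C2=C(O)C(C)C(O)C(C)=C2O1`, built on a different core, gives 6790 nM in this assay. Within the data shown here, the single measured step, a step that the two limits leave unreadable from compound 1 to compound 2, is left unreadable by the two limits, as the limit of > 87000 nM in this assay, at which 2 of the 3 values shown sit, shows. Compound 4 `CCCCC/C=C\C/C=C\CCCCCCCc1cc(=O)c2c(O)cc(OCOC)cc2o1` differs from compound 2 by deca-1,4-dien-1-yl in place of oct-3-en-1-yl on a saturated chain carbon, seven bonds along the chain from an aromatic carbon; no measured step touches the chain, so nothing shown bears on it. Since compound 2 stands at > 87000 nM, compound 4 is expected to stay at the limit in this assay. The estimated step that the limit leaves unreadable from compound 2 to compound 4 is expected to be none beyond the scatter. Compound 4 is estimated at 100000 nM, between 30000 nM and 300000 nM.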

Compound 4, half-maximal inhibitory concentration: > 87000 nM
Compound 4 was reported as a limit; the forecaster's own chance of this, stated with the estimate: 80%; the middle value does not contradict the limit.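

In this assay compound 4 gives > 87000 nM, a limit and not a number, and no step can be read between compound 2, also a limit, and compound 4. The compounds shown leave open whether deca-1,4-dien-1-yl in place of oct-3-en-1-yl changes activity at all.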